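This account rests on a few compounds, and the source may have more. Where it says the series, first, only, none or still open, it means among the compounds named here.

Three analogues on one shared core have been measured in a physicochemical assay for solubility, read by chemiluminescence, in phosphate buffer, measured as kinetic solubility, at pH 7.4; on this read-out higher numbers stand for higher solubility and lower numbers for lower solubility. Compound 1 `O=C(NCC1(c2nc(-c3ccccc3)cs2)CCOCC1)c1ccc(Nc2nc3ccccc3s2)cc1` gives 4000 nM, the lowest of the three numbers. Compound 2 `O=C(NCC1(c2nc(-c3ccccc3)cs2)CCOCC1)c1ccc(Nc2nncs2)cc1` gives 29000 nM, and compound 3 `O=C(NCC1(c2nc(-c3ccccc3)cs2)CCOCC1)c1ccc(-n2ccnc2)cc1` gives 193000 nM. The measured steps read a 7.3-fold higher number from compound 1 to compound 2 (0.86 log units; beyond the scatter) and a 48-fold higher number from compound 1 to compound 3 (1.68 log units; beyond the scatter). Compound 4 `Cc1cnc(Nc2ccc(C(=O)NCC3(c4nc(-c5ccccc5)cs4)CCOCC3)cc2)s1` is next to be measured; it differs from compound 1 by 5-methyl-1,3-thiazol-2-yl in place of 1,3-benzothiazol-2-yl on a nitrogen on an aromatic ring. The step of a 7.3-fold higher number from compound 1 to compound 2 (0.86 log units; beyond the scatter) bears most directly on this change, as both exchange the 1,3-benzothiazol-2-yl for a five-membered aromatic ring with 2 hetero atoms on the same nitrogen. A rise in this assay beyond the scatter is therefore expected for compound 4, as the step of a 3.0-fold higher number from compound 1 to compound 4 (0.48 log units; beyond the scatter). The estimate for compound 4 is 12000 nM, within 4000 nM to 40000 nM.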

Compound 4, solubility: < 1000 nM
Compound 4 ended at the assay's limit (the forecaster's own chance of this, stated with the estimate: 5%); at least 12-fold (1.07 log units) between middle value and limit.
By their numbers in this assay, from the lowest: compound 1; then compound 2; then compound 3. At a limit, below all of these: compound 4.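

In this assay compound 4 stands at a limit of the read-out, not at a number: the limit of < 1000 nM in this assay, at which 1 of the 4 values shown sits. Removing the six-membered aromatic ring of carbon only does not by itself give a rise on this nitrogen, as 5-methyl-1,3-thiazol-2-yl shows an at least 4.0-fold lower number from compound 1 to compound 4 (0.60 log units; beyond the scatter). The five-membered aromatic rings with 2 hetero atoms are not interchangeable here, with an at least 29-fold lower number from compound 2 to compound 4 (1.46 log units; beyond the scatter), and the exchange for 1H-imidazol-1-yl spans an at least 190-fold lower number from compound 3 to compound 4 (2.28 log units; beyond the scatter).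

The compounds shown do not separate the part of the methyl from that of the ring itself. On these data alone, a 1,3-thiazol-2-yl without the methyl, or one carrying a carboxylic acid, remains open.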